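The source may hold more compounds than are shown below. What is called first, only, known or untested is meant among the compounds shown, and "the series" means these compounds.

Compound 1 `Cc1c(OCCCCOc2ccc(C(=O)O)cc2Cl)ccc(C(=O)CC2CCCC2)c1O` gives 120% in an ADME assay on a cell-free system (plasma, Rattus norvegicus) for metabolic stability, read by LC-MS, with a stated time of 60 min, tested at 100 uM (a lower number here means that less of the compound is left, a higher number that more of the compound is left), the higher of the two numbers available, while compound 2 `Cc1c(OCCCCOc2ccc(C(=O)CC(C)(C)C)c(O)c2C)cccc1C(=O)O` gives 89% in this assay, a gap that lies beyond the scatter. Compound 3 `Cc1c(OCCCCOCOc2ccc(C(=O)O)cc2)ccc(C(=O)CC2CCCC2)c1O` has not been measured; it differs from compound 1 in one place: (4-carboxyphenoxy)methyl in place of 4-carboxy-2-chlorophenyl on an oxygen on a saturated carbon. Among the compounds with values here, no measured pair shows this change, so its size is uncertain. Resting on compound 1 at 120%, compound 3 is expected to show a downward step of a number 20 percentage points lower from compound 1 to compound 3 (beyond the scatter), and its value in this assay is estimated at 100%, within 65% to 120%.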

Compound 3, percent of the compound remaining: 100%
Compound 3: the middle estimate sits on the measured number at the digits printed; the measured number falls inside the stated range.
By their numbers in this assay, from the lowest: compound 2; then compound 3; then compound 1.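

The change of 4-carboxy-2-chlorophenyl to (4-carboxyphenoxy)methyl on an oxygen on a saturated carbon shows a number 20 percentage points lower from compound 1 to compound 3 (beyond the scatter) in this assay, the first step read at this place. The number here therefore moves with the group on this oxygen, even though the entering group keeps the six-membered aromatic ring and its carboxy group. Nothing at hand accounts for this step.

This single step cannot separate the loss of the chlorine from the added oxygen and carbon. It also leaves open how an amine in place of the carboxylic acid, or a longer chain on this oxygen, would read.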